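Swapping the Halogen on the Benzyl Ether of Compound 3

The source may hold more compounds than are shown below. What is called first, only, known or untested is meant among the compounds shown, and "the series" means these compounds.

Compound 3 `COc1cc(OC)c(-c2coc3cc(OCc4ccc(Br)cc4)ccc3c2=O)cc1OC` gives 1180 nM in a functional assay on B16 cells (Mus musculus) for antiproliferative activity, read by MTT assay, with a stated time of 24 h (on this read-out higher numbers stand for weaker inhibition and lower numbers for stronger inhibition), the lowest of the two numbers here. Compound 1 `COc1cc(OC)c(-c2coc3cc(OCc4ccccc4)ccc3c2=O)cc1OC` gives 2330 nM in the same assay, and a 2.0-fold lower number from compound 1 to compound 3 (0.30 log units; within the scatter), so these two sit together. Compound 2 `COc1cccc(C(=O)Oc2ccc3c(=O)c(-c4cc(OC)c(OC)cc4OC)coc3c2)c1` is recorded only as a limit of the assay, > 10000 nM. Against it, an at least 4.2-fold higher number from compound 1 to compound 2 (0.63 log units; beyond the scatter) and an at least 8.4-fold lower number from compound 2 to compound 3 (0.92 log units; beyond the scatter). Compound 4 `COc1cc(OC)c(-c2coc3cc(OCc4cccc(Cl)c4)ccc3c2=O)cc1OC` differs from compound 3 by 3-chlorophenyl in place of 4-bromophenyl on a saturated chain carbon bound to an oxygen on an aromatic ring. For the measured compounds named here, the only step touching this part of the molecule is the bromo in place of hydrogen change from compound 1 to compound 3, which stayed within the scatter, so compound 4 is expected to show a 1.3-fold higher number from compound 3 to compound 4 (0.10 log units; within the scatter). The estimated value of compound 4 is 1500 nM, within 600 nM to 3800 nM.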

Compound 4, half-maximal inhibitory concentration: 2280 nM
For compound 4 the middle estimate is 1.5-fold (0.18 log units) below the measured one; measured number inside the range.
By their numbers in this assay, from the lowest: compounds 3, 4 and 1 (each within the scatter of the next). At a limit, above all of these: compound 2.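

Neither the halogen swap nor the halogen itself separates these benzyl ethers in this assay: there is a 1.9-fold higher number from compound 3 to compound 4 (0.29 log units; within the scatter), and a 1.0-fold lower number from compound 1 to compound 4 (0.01 log units; within the scatter). The 3-chlorobenzyl group also stands clear of the (3-methoxyphenyl)carbonyl group, with an at least 4.3-fold lower number from compound 2 to compound 4 (0.64 log units; beyond the scatter), so this gap is not confined to the 4-bromobenzyl group. Compound 2 is recorded only as a limit: the limit of > 10000 nM in this assay, at which 1 of the 4 values shown sits.

Compound 4 changes both the halogen and its ring placement at once, so the two changes cannot be told apart. On these data alone, whether an amine or a carboxylic acid on the benzyl ring, or a longer chain in place of the benzyl group, would move the number beyond the scatter remains open.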